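Changing the amine ring on a shared core

The source may hold more compounds than are shown below. What is called first, only, known or untested is meant among the compounds shown, and "the series" means these compounds.

Measured in a functional assay on V79 cells (Cricetulus griseus) for cytotoxicity, read by colony formation; on this read-out lower numbers stand for stronger inhibition and higher numbers for weaker inhibition:
Compound 1 `COc1c(N2CCC(C)(CN)C2)c(F)cc2c(=O)c(C(=O)O)cn(C3CC3)c12` gives 38 ug/mL
Compound 2 `COc1c(N2CC(C)NC(C)C2)c(F)cc2c(=O)c(C(=O)O)cn(C3CC3)c12` gives > 500 ug/mL, a limit and not a number

Compound 2 therefore stands at the limit of > 500 ug/mL in this assay, at which 1 of the 2 values shown sits. Compound 3 `COc1c(N2CCCC(N)C2)c(F)cc2c(=O)c(C(=O)O)cn(C3CC3)c12` differs from it by one change: 3-aminopiperidin-1-yl in place of 3,5-dimethylpiperazin-1-yl on an aromatic carbon. Among the measured compounds shown here, the one measured step bearing on this is an at least 13-fold higher number from compound 1 to compound 2 (1.11 log units; beyond the scatter), which brought in the same 3,5-dimethylpiperazin-1-yl group. Compound 3 carries an amino group on its new ring substituent, as compound 1 at 38 ug/mL does on its own, so a clearly lower number, beyond the scatter, is expected in this assay. The expected step is an at least 7.1-fold lower number from compound 2 to compound 3 (0.85 log units; beyond the scatter). For compound 3 the estimate is 70 ug/mL, with an expected range of 15 ug/mL to 300 ug/mL.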

Compound 3, half-maximal inhibitory concentration: 69 ug/mL
Compound 3: the middle estimate sits 1.0-fold (0.01 log units) above what was measured; the measured number falls inside the stated range.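

In this assay, an amino-bearing ring at this position on the shared core separates clearly from the 3,5-dimethylpiperazin-1-yl group, with an at least 7.2-fold lower number from compound 2 to compound 3 (0.86 log units; beyond the scatter). Compound 2 is a limit and not a number, so this step has only a lower bound: the limit of > 500 ug/mL in this assay, at which 1 of the 3 values shown sits.

Exchanging 3-(aminomethyl)-3-methylpyrrolidin-1-yl for 3-aminopiperidin-1-yl stays within the scatter, with a 1.8-fold higher number from compound 1 to compound 3 (0.26 log units; within the scatter).

The compounds shown leave open whether the amino group itself carries the difference from compound 2. A 3-hydroxypiperidin-1-yl or plain piperidin-1-yl group at the same place would bear on that.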